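The source may report more compounds than this note shows. Statements on the series, on what has been measured and on what is new or still open speak of the compounds shown alone.

Measured compounds:
compound 1 `CN(Cc1cc(-c2ccccc2Cl)no1)C(=O)C1CCNCC1` — 350 nM
compound 2 `Cc1c(-c2cc(-c3ccccc3Cl)no2)cnn1C1CCNCC1` — 18 nM
compound 3 `c1ccc(-c2cc(-c3cnn(C4CCNCC4)c3)on2)cc1` — 100000 nM

In an assay on isolated protein for positive allosteric modulation of Neuronal acetylcholine receptor; alpha4/beta2 (Homo sapiens) (a lower number here means that less compound is needed, a higher number that more compound is needed for the effect), compound 2 gives the lowest of the three numbers. Compound 1 lies well beyond the scatter above it, and compound 3 lies very far above both; those two pairs share no single structural change, so their values stand only as they are.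

Compound 4 `Cc1c(-c2cc(-c3ccccc3)no2)cnn1C1CCNCC1` is not yet measured. It differs from compound 2 by hydrogen in place of chloro on an aromatic carbon. For the measured compounds named here, no measured pair shows this change on its own, so the expectation rests on the change alone. In this assay the step from compound 2 to compound 4 is expected to be a 5.6-fold higher number from compound 2 to compound 4 (0.74 log units; beyond the scatter), a moderate rise beyond the scatter.

Compound 4 is therefore expected to give 100 nM, within a range of 20 nM to 600 nM.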

Compound 4, half-maximal effective concentration: 1200 nM
The estimate for compound 4 lay 12-fold (1.08 log units) below the measured number; measured number outside the range, above it.
By their numbers in this assay, from the lowest: compound 2; then compound 1; then compound 4; then compound 3.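

In this assay, hydrogen in place of chloro on the aromatic carbon gives a 67-fold higher number from compound 2 to compound 4 (1.82 log units; beyond the scatter) and marks the chloro, ortho to a large group, as a large contributor in this series. Methyl in place of hydrogen on the other aromatic carbon gives an 83-fold lower number from compound 3 to compound 4 (1.92 log units; beyond the scatter) and shows that this second place also carries a large step on its own. No available measurement explains either step.

From the compounds shown here alone, whether fluoro, bromo or methoxy can stand in for the chloro remains open. So does the outcome with ethyl or cyclopropyl in place of the methyl.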